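This account rests on a few compounds, and the source may have more. Where it says the series, first, only, none or still open, it means among the compounds named here.

Measured in a functional assay on A549 cells (Homo sapiens) for cytotoxicity, read by MTT assay, with a stated time of 72 h; on this read-out higher numbers stand for weaker inhibition and lower numbers for stronger inhibition:
Compound 1 `COc1cccc(/C=C2\CCC/C(=C\c3ccccc3Cl)C2=O)c1OC`: > 20000 nM, a limit.
Compound 2 `COc1cccc(/C=C2\CCC/C(=C\c3cc(Cl)cc(Cl)c3)C2=O)c1OC`: 12500 nM.
Compound 3 `COc1ccc(/C=C2\CCC/C(=C\c3ccccc3Cl)C2=O)cc1OC`: > 20000 nM, a limit.

Compound 3 has no number in this assay, only the limit > 20000 nM. It sits at the limit of > 20000 nM in this assay, at which 2 of the 3 values shown sit.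

Compound 4 `COc1ccc(/C=C2\CCC/C(=C\c3ccc(Cl)cc3)C2=O)cc1OC` keeps the core of compound 3 and carries 4-chlorophenyl in place of 2-chlorophenyl on a double-bonded chain carbon bound to a double-bonded ring carbon.

Within the data shown here, the only measured step that bears on this change is an at least 1.6-fold lower number from compound 1 to compound 2 (0.20 log units; that floor lies within the scatter). That step also replaces 2-chlorophenyl, but 3,5-dichlorophenyl enters there, and on the core of compound 1, so it is only a loose guide. On that basis, a small move towards a lower number is expected, perhaps none beyond the scatter. The expected size is an at least 1.3-fold lower number from compound 3 to compound 4 (0.12 log units; that floor lies within the scatter). Compound 4 may again reach only a limit. The estimate for compound 4 is 15000 nM, with an expected range from 7000 nM to 20000 nM.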

Compound 4, half-maximal inhibitory concentration: 10100 nM
Compound 4: the middle estimate sits 1.5-fold (0.17 log units) above what was measured; low and high end bracket the measured number.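

In this assay, 4-chlorophenyl in place of 2-chlorophenyl on the core of compound 3 gives an at least 1.9-fold lower number from compound 3 to compound 4 (0.29 log units; that floor lies within the scatter). This shows that a single chlorine, with the same atoms overall, can bring a measured number at this place, without the second chlorine that the 3,5-dichlorophenyl of compound 2 carries on the core of compound 1. Compound 3 has only a limit, so the true size of this step cannot be told: the limit of > 20000 nM in this assay, at which 2 of the 4 values shown sit.

The compounds shown leave open whether 4-chlorophenyl would also give a measured number on the core of compound 1. They also leave open how this place would respond to a phenyl ring carrying an amine or a carboxylic acid instead of chlorine.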